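The compounds below may be only part of what the source reports. "The series", "measured", "known", "first", "only" and "open" are said of these compounds alone.

Working notes on the series in a functional assay on A549 cells (Homo sapiens) for inhibition, read by MTT assay, with a stated time of 72 h; a lower number here means a stronger inhibitor, a higher number a weaker inhibitor.

Of the compounds shown here, three share the core and have numbers so far. Compound 1 `O=C(Nc1ccc(Oc2ccnc3[nH]ccc23)cc1)c1cn(-c2ccc(C(F)(F)F)cc2Cl)c2ccccc2c1=O` gives 2350 nM in this assay. Compound 2 `O=C(Nc1ccc(Oc2ccnc3[nH]ccc23)c(F)c1)c1cn(-c2ccccc2)c2ccccc2c1=O` gives 420 nM. Compound 3 `O=C(Nc1ccc(Oc2ccnc3[nH]ccc23)c(F)c1)c1cn(-c2ccc(Cl)cc2)c2ccccc2c1=O` gives 320 nM, the lowest of the three numbers; the gap to compound 2 is within the scatter, the gap to compound 1 is beyond it.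

Among the measured compounds shown here, the one step measured in one place, a 1.3-fold lower number from compound 2 to compound 3 (0.12 log units; within the scatter), concerns the phenyl on the aromatic nitrogen and did not move the number beyond the scatter.

Compound 4 `O=C(Nc1ccc(Oc2ccnc3[nH]ccc23)c(F)c1)c1cn(-c2ccc(C(F)(F)F)cc2Cl)c2ccccc2c1=O` has not been measured. It differs from compound 3 by 2-chloro-4-(trifluoromethyl)phenyl in place of 4-chlorophenyl on an aromatic nitrogen. For the measured compounds named here, no measured step covers this exact change. Going by the values given here, the group that enters is the one carried by compound 1, which differs from compound 4 only by the fluoro on the anilide ring; the two values of compound 1 and compound 3 stand beyond the scatter, with compound 1 the higher number. Against that, the fluoro-bearing compounds 2 and 3 both sit at lower numbers than compound 1. The step of a 4.4-fold higher number from compound 3 to compound 4 (0.64 log units; beyond the scatter) is therefore expected to be upward in this assay. Compound 4 is estimated at 1400 nM, with a range from 450 nM to 4500 nM.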

Compound 4, half-maximal inhibitory concentration: 1620 nM
Compound 4: the middle estimate sits 1.2-fold (0.06 log units) below what was measured; measured number inside the range.
By their numbers in this assay, from the lowest: compounds 3 and 2 (each within the scatter of the next); then compounds 4 and 1 (each within the scatter of the next).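

In this assay, the group on the aromatic nitrogen now gives steps beyond the scatter: a 5.1-fold higher number from compound 3 to compound 4 (0.70 log units; beyond the scatter) and a 3.9-fold higher number from compound 2 to compound 4 (0.59 log units; beyond the scatter), both upward, whereas the earlier chloro step on the same phenyl stayed within the scatter. The matched pair for the fluoro, a 1.5-fold lower number from compound 1 to compound 4 (0.16 log units; within the scatter), stays within the scatter, so among these four compounds the gap between compound 1 and compounds 2 and 3 follows the group on the aromatic nitrogen and not the fluoro. Nothing at hand explains why 2-chloro-4-(trifluoromethyl)phenyl gives the higher numbers.

Going by these compounds, in these compounds the 2-chloro and the 4-trifluoromethyl arrive together, so it remains open whether one of them alone accounts for the upward steps or whether both are needed. Also open, on these data alone, is how this assay would read a phenyl on the aromatic nitrogen carrying a methoxy group, an amine or a carboxylic acid, and whether the fluoro stays within the scatter with such groups in place.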